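The compounds below may be only part of what the source reports. "The series", "measured", "known", "first", "only" and "open" are said of these compounds alone.

Working notes on the sulfamate series. Of the compounds shown here, two have been measured in an assay on HEK293 cells for inhibition of Steryl-sulfatase (Homo sapiens), tested at 1 uM; a lower number here means a weaker effect, a higher number a stronger effect of the compound at the concentration tested: compound 1 `NS(=O)(=O)Oc1ccc2c(c1)CN(C(=O)c1cccc(N3CCN(c4ncccn4)CC3)c1)CC2` and compound 2 `CCN(Cc1ccc(Br)cc1)c1cccc(C(=O)N2CCc3ccc(OS(N)(=O)=O)cc3C2)c1`. In this assay compound 1 gives 24.4%, while compound 2 gives 84.5%. Compound 2 therefore carries the higher of the two values, and its gap to compound 1 lies beyond the usual scatter.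

Compound 3 `NS(=O)(=O)Oc1ccc2c(c1)CN(C(=O)c1cccc(N3CCc4ccccc4C3)c1)CC2` has not been measured in this assay. Relative to compound 2 the change is 1,2,3,4-tetrahydroisoquinolin-2-yl in place of (4-bromobenzyl)(ethyl)amino on an aromatic carbon. For the measured compounds named here, no pair of measured compounds differing only in this way exists, so the size of the step cannot be read from a parallel case; the two measured values merely show how wide the span in this assay can be.

A downward step from compound 2 to compound 3 of moderate size is expected, a number 29.5 percentage points lower from compound 2 to compound 3 (beyond the scatter). The estimate for compound 3 in this assay is 55%, with a range from 25% to 82%.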

Compound 3, a percentage reported as inhibition, at one concentration (the size of the read-out at that concentration, not a potency): 50.2%
For compound 3 the middle estimate is 4.8 percentage points above the measured one; measured number inside the range.
By their numbers in this assay, from the lowest: compound 1; then compound 3; then compound 2.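

In this assay, 1,2,3,4-tetrahydroisoquinolin-2-yl in place of (4-bromobenzyl)(ethyl)amino on an aromatic carbon gives a number 34.3 percentage points lower from compound 2 to compound 3 (beyond the scatter). For the compounds shown here, this is the first step read at this position, and it is large even though both groups hold one six-membered aromatic ring of carbon only and the same donor and acceptor counts; the entering group has no bromine and holds its nitrogen in a six-membered non-aromatic ring. No measurement at hand accounts for the drop.

The compounds shown leave open whether the bromine, the ethyl group or the open-chain benzylamino arrangement goes with the higher value of compound 2. An unsubstituted benzyl or a 4-chlorobenzyl group on the same ethylamino nitrogen would separate these parts.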